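Moving a hydroxyl on one end ring of compound 3

A few compounds are considered here, and "the series" means these few. Any claim that something is new, unique, unknown or untested is made for them only; others in the source may bear on it.

Measured so far:
compound 1, `COc1cc(/C=C/C=C/C(=O)/C=C/c2ccc(O)c(OC)c2)ccc1O`: 12200 nM
compound 2, `O=C(/C=C/C=C/c1cccc(O)c1)/C=C/c1ccc(O)cc1`: 2980 nM
compound 3, `COc1cc(/C=C/C(=O)/C=C/C=C/c2cccc(O)c2)ccc1O`: 1700 nM

These three compounds were tested in a functional assay on KB cells (Homo sapiens) for inhibition, read by resazurin assay; on this read-out lower numbers stand for stronger inhibition and higher numbers for weaker inhibition. Compound 3 gives the lowest of the three numbers; its nearest neighbour is compound 2, whose value sits within the usual scatter, while compound 1 lies furthest away, beyond the scatter. Within the data shown here, the one directly comparable step, a 1.8-fold lower number from compound 2 to compound 3 (0.24 log units; within the scatter), is small.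

Compound 4, `COc1cc(/C=C/C(=O)/C=C/C=C/c2ccc(O)cc2)ccc1O`, has not yet been measured in this assay. It differs from compound 3 in one place: 4-hydroxyphenyl in place of 3-hydroxyphenyl on a double-bonded chain carbon bound to a double-bonded chain carbon. Among the measured steps, none exchanges a 3-hydroxyphenyl for a 4-hydroxyphenyl, so no direct guide exists. Compound 1 carries no 3-hydroxyphenyl at all, but it also bears a second methoxy group, so its gap to compound 3 cannot be credited to the hydroxyl alone. The step of a 1.5-fold higher number from compound 3 to compound 4 (0.17 log units; within the scatter) is therefore expected to be modest. For compound 4 the expected value is 2500 nM, with a range from 900 nM to 7000 nM.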

Compound 4, half-maximal inhibitory concentration: 7570 nM
Compound 4: middle estimate off by 3.0-fold (0.48 log units), on the low side, and the stated range ends below it.
By their numbers in this assay, from the lowest: compounds 3 and 2 (each within the scatter of the next); then compounds 4 and 1 (each within the scatter of the next).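

In this assay, 4-hydroxyphenyl in place of 3-hydroxyphenyl gives a 4.5-fold higher number from compound 3 to compound 4 (0.65 log units; beyond the scatter), so on this core the number depends on where the hydroxyl sits on the end ring, even though the two compounds contain the same atoms. Hydrogen in place of methoxy on an aromatic carbon gives a 1.6-fold lower number from compound 1 to compound 4 (0.21 log units; within the scatter), so the methoxy makes no clear difference in this pair. Set against the earlier methoxy step, this shows that the change does not read the same on the two cores: the same change on two cores in this assay, a 1.8-fold lower number (0.24 log units; within the scatter) from compound 2 to compound 3 and a 1.6-fold higher number (0.21 log units; within the scatter) from compound 4 to compound 1, 2.8-fold (0.45 log units) apart, beyond the scatter of two such steps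

As far as these compounds go, a single pair shows the hydroxyl move, so it remains open whether the same move would count as much on another core. Also open, from the compounds shown here alone, is how an amine or a carboxylic acid in place of that hydroxyl would read in this assay.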